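This account rests on a few compounds, and the source may have more. Where it says the series, first, only, none or still open, it means among the compounds named here.

Measured so far in a functional assay on the whole organism (strain Swiss) with Mus musculus as the target, in the maximal electroshock model, with a stated time of 2 h, at a dose of 300 mg/kg by the intraperitoneal route; a lower number here means a weaker effect, a higher number a stronger effect of the compound at the dose given:
- compound 1, `COc1cccc(N2CCN(C(=O)C(C)N3C(=O)CCC3=O)CC2)c1`: 0%
- compound 2, `CCC(C(=O)N1CCN(c2cccc(OC)c2)CC1)N1C(=O)CCC1=O`: 0%
- compound 3, `CC(C(=O)N1CCN(c2ccccc2C(F)(F)F)CC1)N1C(=O)CCC1=O`: 75%

Compound 1 and compound 2 share a core and differ only by methyl in place of hydrogen on a saturated chain carbon, two bonds along the chain from an amide-type nitrogen in a ring and a carbonyl carbon. The step of no change at the digits printed from compound 1 to compound 2 (within the scatter) shows that this change left the read-out where it was, though both numbers sit at the bottom of the scale, so the step says little about what the same change would do to a compound that shows an effect. Compound 3 stands on a different core; the difference between the core of compound 3 and the core of compound 1 is not broken down here. Compound 3 gives the highest number of the three, and its gap to compound 1 and to compound 2 is beyond the scatter.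

Compound 4, `CCC(C(=O)N1CCN(c2ccccc2C(F)(F)F)CC1)N1C(=O)CCC1=O`, is not yet measured. It differs from compound 3 by methyl in place of hydrogen on a saturated chain carbon, two bonds along the chain from an amide-type nitrogen in a ring and a carbonyl carbon, which is the same change as that from compound 1 to compound 2, at the same place, with the same group leaving and entering. Since the step of no change at the digits printed from compound 1 to compound 2 (within the scatter) was flat, the expectation is that compound 4 keeps much of the effect of compound 3, with a step of a number 10 percentage points lower from compound 3 to compound 4 (within the scatter) expected; the range is kept wide because the earlier step started from a floor. Compound 4 is therefore estimated at 65%, between 25% and 100%.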

Compound 4, a percentage reported as activity, at one dose (the size of the read-out at that dose, not a potency): 0%
For compound 4 the middle estimate is 65 percentage points above the measured one, outside the stated range (below it).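

In this assay, methyl in place of hydrogen on a saturated chain carbon, two bonds along the chain from an amide-type nitrogen in a ring and a carbonyl carbon, gives a number 75 percentage points lower from compound 3 to compound 4 (beyond the scatter), so the outcome of this change does not carry from one core to another in this series: the same change on two cores in this assay, no change at the digits printed (within the scatter) from compound 1 to compound 2 and a number 75 percentage points lower (beyond the scatter) from compound 3 to compound 4, 75 percentage points apart, beyond the scatter of two such steps

The flat earlier step is weak evidence of tolerance, since compound 1 gives 0% and compound 2 gives 0%, and a step that starts at the bottom of the scale cannot show a further fall; the two cores may therefore respond alike, with the loss visible only on the core of compound 3. The result rests on a single pair at one dose and one time in this assay, so it shows a loss of effect under those conditions, gives no potency, and does not explain the loss.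

The compounds shown leave open how a propyl chain or a cyclopropyl group at the same place would read on the core of compound 3. They also leave open whether the same change would remove the effect on a core carrying a chlorine atom in place of trifluoromethyl.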